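A few compounds are considered here, and "the series" means these few. Any claim that something is new, unique, unknown or untested is made for them only; others in the source may bear on it.

Compound 1 `Cc1cc(N2CC[C@@H](C)[C@@H](N(C)c3ncnc4[nH]ccc34)C2)n2ncnc2n1`: 67400 nM
Compound 2 `CCCSc1nc2nc(C)cc(N3CC[C@@H](C)[C@@H](N(C)c4ncnc5[nH]ccc45)C3)n2n1`: 51200 nM
Compound 3 `CCc1cc(N2CC[C@@H](C)[C@@H](N(C)c3ncnc4[nH]ccc34)C2)n2ncnc2n1`: 82200 nM

In a functional assay on BGC-823 cells (Homo sapiens) for inhibition, read by MTT assay, with a stated time of 72 h (a lower number here means a stronger inhibitor, a higher number a weaker inhibitor), compound 1 stands second highest of the three numbers. Its nearest neighbour is compound 3, with a 1.2-fold higher number from compound 1 to compound 3 (0.09 log units; within the scatter); furthest is compound 2, with a 1.3-fold lower number from compound 1 to compound 2 (0.12 log units; within the scatter). Compound 4 `Cc1cc(N2CC[C@@H](C)[C@@H](N(C)c3ncnc4[nH]ccc34)C2)n2nc(SCC3CC3)nc2n1` differs from compound 1 in one place: (cyclopropylmethyl)sulfanyl in place of hydrogen on an aromatic carbon. The step that bears most directly on this is the one in which propylsulfanyl replaces hydrogen on an aromatic carbon, a 1.3-fold lower number from compound 1 to compound 2 (0.12 log units; within the scatter), which stayed within the scatter; the change to compound 3 is at a saturated chain carbon and also stayed within the scatter. A (cyclopropylmethyl)sulfanyl group is therefore expected to leave this assay essentially unchanged, with any shift no larger than the scatter. Compound 4 is expected to give 55000 nM, in the range 25000 nM to 120000 nM. The expected step is a 1.2-fold lower number from compound 1 to compound 4 (0.09 log units; within the scatter).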

Compound 4, half-maximal inhibitory concentration: 36500 nM
Estimate against measurement, compound 4: 1.5-fold (0.18 log units) above; measured number inside the range.
By their numbers in this assay, from the lowest: compounds 4, 2, 1 and 3 (each within the scatter of the next, the first and the last beyond it).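

In this assay, (cyclopropylmethyl)sulfanyl on the aromatic carbon between two ring nitrogen atoms gives a 1.8-fold lower number from compound 1 to compound 4 (0.27 log units; within the scatter), so a second sulfur-linked group at this position leaves the shift within the scatter. Cyclopropyl in place of ethyl on the saturated chain carbon bound to the sulfur gives a 1.4-fold lower number from compound 2 to compound 4 (0.15 log units; within the scatter), so these two chains are not told apart here. Nothing available explains either step.

On these data alone, whether an amine or a carboxylic acid on this carbon would move the number in this assay beyond the scatter remains open.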